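The compounds below may be only part of what the source reports. "The series", "measured", "known", "first", "only" and "open" are said of these compounds alone.

Measured so far:
- compound 1 `O=C(Nc1nc2ccc(C(F)(F)F)cc2s1)C1CC1`: > 50000 nM
- compound 2 `O=C(Nc1nc2cc(F)c(C(F)(F)F)cc2s1)C1CC1`: > 50000 nM
- compound 3 `CC(C)(F)C(=O)Nc1nc2ccc(C(F)(F)F)cc2s1`: > 50000 nM

In an ADME assay on H9c2 cells (Rattus norvegicus) for cytotoxicity (on this read-out lower numbers stand for stronger inhibition and higher numbers for weaker inhibition), compound 1 gives > 50000 nM, which is a limit of the assay and not a number. In this assay compound 2 gives > 50000 nM, also a limit of the assay. In this assay compound 3 gives > 50000 nM, again a limit of the assay.

The change from compound 1 to compound 2 is fluoro in place of hydrogen on an aromatic carbon and its step reads a step that the two limits leave unreadable from compound 1 to compound 2. The change from compound 1 to compound 3 is 1-fluoro-1-methylethyl in place of cyclopropyl on a carbonyl carbon and its step reads a step that the two limits leave unreadable from compound 1 to compound 3. Both steps stand between two limits because of the limit of > 50000 nM in this assay, at which 3 of the 3 values shown sit, so neither has a readable size.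

Compound 4 `CC(C)(F)C(=O)Nc1nc2cc(F)c(C(F)(F)F)cc2s1` is not yet measured. Among the compounds with values here, it differs from compound 3 by fluoro in place of hydrogen on an aromatic carbon, the same change as the one from compound 1 to compound 2, made around the same place. The two cores differ by 1-fluoro-1-methylethyl in place of cyclopropyl on a carbonyl carbon.

Beside a step that the two limits leave unreadable from compound 1 to compound 2, the step expected from compound 3 to compound 4 in this assay is a step that the limit leaves unreadable from compound 3 to compound 4; this expectation rests on compound 3 sitting at > 50000 nM and on compound 2 sitting at > 50000 nM, both limits. Compound 4 is accordingly expected to give about 70000 nM in this assay, most likely reported again as a limit, with a range estimated from 30000 nM to 250000 nM.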

Compound 4, half-maximal inhibitory concentration: > 50000 nM
Compound 4: only a limit was reported; the forecaster's own chance of this, stated with the estimate: 85%; the middle value does not contradict the limit.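

In this assay compound 4 gives > 50000 nM as a limit of the assay and not a number. Neither the step from compound 3 to compound 4 nor the step from compound 2 to compound 4 can be read, for this reason: the limit of > 50000 nM in this assay, at which 4 of the 4 values shown sit 

The compounds shown leave open whether fluoro in place of hydrogen, or 1-fluoro-1-methylethyl in place of cyclopropyl, shifts the result in this assay at all.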